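The source may hold more compounds than are shown below. What is called first, only, known or untested is meant among the compounds shown, and "the series" means these compounds.

Measured so far in an assay on isolated protein for displacement of a labelled ligand from metabotropic glutamate receptor 5 (Homo sapiens), with a stated time of 60 min, tested at 1 uM; on this read-out higher numbers stand for more inhibition at the one concentration tested (going by the name of the read-out) and lower numbers for less inhibition:
- compound 1 `COc1ccc2ncc(S(=O)(=O)c3ccc(Cl)c(Cl)c3)c(N3CCC(C)CC3)c2c1`: 87%
- compound 2 `CC1CCN(c2c(S(=O)(=O)c3ccc(Cl)c(Cl)c3)cnc3ccc(Cl)cc23)CC1`: 86%

Compound 2 stands lowest of the two numbers, with compound 1 nearest, the gap from compound 1 to compound 2 being a number 1 percentage points lower from compound 1 to compound 2 (within the scatter) and so within the scatter. The next compound, compound 3 `Cc1ccc2ncc(S(=O)(=O)c3ccc(Cl)c(Cl)c3)c(N3CCC(C)CC3)c2c1`, is not yet measured. It differs from compound 2 by methyl in place of chloro on an aromatic carbon. Among the measured compounds shown here, the one measured step that bears on this position is a number 1 percentage points lower from compound 1 to compound 2 (within the scatter), which shows that exchanging methoxy for chloro at this aromatic carbon left this assay essentially unchanged. Methyl in place of chloro at the same carbon is therefore expected to give no step beyond the scatter; the step from compound 2 to compound 3 is estimated at a number 2 percentage points lower from compound 2 to compound 3 (within the scatter). Compound 3 is expected to give about 84%, with a range from 70% to 95%.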

Compound 3, a percentage reported as inhibition, at one concentration (the size of the read-out at that concentration, not a potency): 82%
Estimate against measurement, compound 3: 2 percentage points above, within the range that was stated.
By their numbers in this assay, from the lowest: compounds 3, 2 and 1 (each within the scatter of the next).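

Methyl is a third group on this aromatic carbon, after chloro and methoxy, and the steps of a number 4 percentage points lower from compound 2 to compound 3 (within the scatter) and a number 5 percentage points lower from compound 1 to compound 3 (within the scatter) in this assay leave all three unseparated. A group with a single carbon attached directly to the ring therefore fits the same picture as the chlorine and the oxygen-linked methoxy, and no listed change at this position moves the reading beyond the scatter. No supporting measurement bears on why these three groups read alike.

From the compounds shown here alone, whether a larger group, such as a carboxylic acid or an amine, would also leave the reading in place on this carbon remains open. Going by these compounds, the readings come from one concentration, so whether compound 1, compound 2 and compound 3 would show a stronger or weaker effect than one another at any other concentration also remains open.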